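Shortening a 2-(pyridin-2-yl)ethoxy chain to allyloxy

The source may report more compounds than this note shows. Statements on the series, on what has been measured and on what is new or still open speak of the compounds shown alone.

Measured compounds:
Compound 1, `CS(=O)(=O)Nc1cccc(C(=O)N2CCCC(C(=O)Nc3ccc(Cl)cc3)C2)c1`: 3%
Compound 2, `O=C(Nc1cccc(OCCc2ccccn2)c1)C1CCCN(C(=O)c2cc(C(F)(F)F)cc(C(F)(F)F)c2)C1`: 5%
Compound 3, `O=C(Nc1ccc(Cl)cc1)C1CCCN(C(=O)c2cccc(-c3cccs3)c2)C1`: 4%

All three compounds were tested in an ADME assay on PC-3 cells (Homo sapiens) for cytotoxicity, read by WST assay, tested at 100 uM; a lower number here means less inhibition, a higher number more inhibition at the concentration tested (going by the name of the read-out). The three numbers sit close together: the gaps from compound 2 to compound 3 and from compound 2 to compound 1 both lie within the usual scatter, so compound 2 is not separated from either of its neighbours on this read-out.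

For the measured compounds named here, the only step measured between compounds that differ in one place is a number 1 percentage points higher from compound 1 to compound 3 (within the scatter), and it stays within the scatter.

Compound 4, `C=CCOc1cccc(NC(=O)C2CCCN(C(=O)c3cc(C(F)(F)F)cc(C(F)(F)F)c3)C2)c1`, has not yet been measured in this assay. It differs from compound 2 by vinyl in place of (pyridin-2-yl)methyl on a saturated chain carbon bound to an oxygen on an aromatic ring. Going by the values given here, no measured step touches this part of the shared core, so the expectation can rest only on the general flatness of the three numbers so far. No step beyond the scatter is expected.

Compound 4 is therefore estimated to give 5%, with a range from 0% to 15%. This estimate amounts to an expected no change at the digits printed from compound 2 to compound 4 (within the scatter), a step expected to remain within the scatter.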

Compound 4, a percentage reported as inhibition, at one concentration (the size of the read-out at that concentration, not a potency): 0%
Beside the measured number, compound 4's estimate is 5 percentage points above it, and the stated range covers the measured number.
By their numbers in this assay, from the lowest: compounds 4, 1, 3 and 2 (each within the scatter of the next).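

In this assay, the first step read at this position is a number 5 percentage points lower from compound 2 to compound 4 (within the scatter), so cutting 2-(pyridin-2-yl)ethoxy back to allyloxy does not separate the two compounds on this read-out. The six-membered aromatic ring and its hydrogen-bond acceptor can thus leave this chain without a step that stands beyond the scatter, at the one concentration tested. No evidence bearing on this result is at hand.

On these data alone, it remains open whether other groups on this oxygen, such as a plain methyl, or a chain ending in an amine or a carboxylic acid, would stay as flat. The compounds shown also leave open whether any replacement at this position could move the number beyond the scatter from compound 2 at all.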